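Methoxy for methyl: a one-step note on the series

The compounds below may be only part of what the source reports. "The series", "measured", "known", "first", "only" and "open" are said of these compounds alone.

Measured so far:
compound 1 `c1ccc(NN=C(c2nc3ccccc3[nH]2)c2nc3ccccc3[nH]2)cc1` — 13000 nM
compound 2 `Cc1ccc(NN=C(c2nc3ccccc3[nH]2)c2nc3ccccc3[nH]2)cc1` — 26500 nM

In a functional assay on CCRF-CEM cells (Homo sapiens) for cytotoxicity, read by MTT assay, with a stated time of 72 h (a lower number here means a stronger inhibitor, a higher number a weaker inhibitor), compound 2 gives 26500 nM, the higher of the two numbers at hand. Among the measured compounds shown here, its only neighbour is compound 1, and the change a 2.0-fold higher number from compound 1 to compound 2 (0.31 log units; beyond the scatter) is the sole measured step in the set.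

Compound 3 `COc1ccc(NN=C(c2nc3ccccc3[nH]2)c2nc3ccccc3[nH]2)cc1` differs from compound 2 by methoxy in place of methyl on an aromatic carbon. For the measured compounds named here, no measured pair covers this exchange; the hydrogen-to-methyl step above is the only guide, and it shows that a small group at this position moves the number by a modest amount. A methoxy at the same place is expected to land near compound 2, with a step of a 1.3-fold lower number from compound 2 to compound 3 (0.12 log units; within the scatter) that may not exceed the scatter. Compound 3 is therefore expected to give about 20000 nM in this assay. The estimated range for compound 3 runs from 8000 nM to 50000 nM.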

Compound 3, half-maximal inhibitory concentration: 10900 nM
The estimate for compound 3 lay 1.8-fold (0.26 log units) above the measured number, within the range that was stated.
By their numbers in this assay, from the lowest: compounds 3 and 1 (each within the scatter of the next); then compound 2.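

In this assay the exchange of methyl for methoxy on the aromatic carbon para to a large group gives a 2.4-fold lower number from compound 2 to compound 3 (0.39 log units; beyond the scatter), which runs opposite to the earlier step, a 2.0-fold higher number from compound 1 to compound 2 (0.31 log units; beyond the scatter). Methoxy in place of hydrogen gives a 1.2-fold lower number from compound 1 to compound 3 (0.08 log units; within the scatter), so among these three groups only the methyl of compound 2 stands apart, and compound 3 goes against any rise in the number with the heavy-atom count of the group. Nothing at hand explains why methyl and methoxy differ at this place.

Going by these compounds, whether an amine, a hydroxyl or a longer chain such as ethoxy at this place would fall with hydrogen and methoxy or with methyl stays open. Also open, on these data alone, is whether the methyl-to-methoxy step holds elsewhere on this ring or with chlorine as the comparison group.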